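Aryl swap on the ring nitrogen: what to expect for compound 4

The compounds below may be only part of what the source reports. "The series", "measured", "known", "first", "only" and "open" are said of these compounds alone.

compound 1 `Nc1scc(CN2CCN(c3ccc(Cl)cc3Cl)CC2)c1C(=O)c1ccc(Cl)cc1` — -54%
compound 2 `Nc1scc(CN2CCN(c3ccc(Cl)cc3F)CC2)c1C(=O)c1ccc(Cl)cc1` — -57%
compound 3 `Nc1scc(CN2CCN(c3ccc([N+](=O)[O-])cc3)CC2)c1C(=O)c1ccc(Cl)cc1` — -8.3%

In a functional assay on CHO cells with adenosine receptor A1 (Homo sapiens) as the target, read by cAMP accumulation and immunoassay, with a stated time of 6 min, tested at 1 uM (a lower number here means a stronger effect, a higher number a weaker effect of the compound at the concentration tested), compound 1 stands second highest of the three numbers; the nearest step is a number 3 percentage points lower from compound 1 to compound 2 (within the scatter), the furthest is a number 45.7 percentage points higher from compound 1 to compound 3 (beyond the scatter). Compound 4 `Nc1scc(CN2CCN(c3cccc(C(F)(F)F)c3)CC2)c1C(=O)c1ccc(Cl)cc1` differs from compound 1 in one place: 3-(trifluoromethyl)phenyl in place of 2,4-dichlorophenyl on an amine nitrogen in a ring. Within the data shown here, two measured steps bear on this kind of change, both exchanges of the aryl group on the ring nitrogen: a number 45.7 percentage points higher from compound 1 to compound 3 (beyond the scatter) and a number 48.7 percentage points higher from compound 2 to compound 3 (beyond the scatter). By contrast, fluoro in place of chloro on an aromatic carbon gives only a number 3 percentage points lower from compound 1 to compound 2 (within the scatter). The entering aryl is neither chloro-bearing like those of compound 1 and compound 2 nor nitro-bearing like that of compound 3, so a step of uncertain size, most likely upward, is expected: a number 19 percentage points higher from compound 1 to compound 4 (beyond the scatter). Compound 4 is therefore estimated at -35%, range -60% to -5%.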

Compound 4, a percentage reported as activity, at one concentration (the size of the read-out at that concentration, not a potency): -72%
For compound 4 the middle estimate is 37 percentage points above the measured one; measured number below the stated range.
By their numbers in this assay, from the lowest: compound 4; then compounds 2 and 1 (each within the scatter of the next); then compound 3.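

In this assay, the aryl exchange on the ring nitrogen can also lower the number: 3-(trifluoromethyl)phenyl gives a number 18 percentage points lower from compound 1 to compound 4 (beyond the scatter) and a number 15 percentage points lower from compound 2 to compound 4 (beyond the scatter), whereas the earlier aryl exchanges only raised it. Among these compounds, a chlorine-bearing aryl is therefore not required for the lowest number in this set, and a number 63.7 percentage points lower from compound 3 to compound 4 (beyond the scatter) is the widest span at this position so far. No measurement at hand accounts for these steps.

The compounds shown leave open how a pyridine ring, a benzyl group or a methoxy-bearing phenyl on the ring nitrogen would compare. As far as these compounds go, with a single tested concentration, potency also remains open.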